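A few compounds are considered here, and "the series" means these few. Any claim that something is new, unique, unknown or untested is made for them only; others in the source may bear on it.

Compound 2 `CCc1ccc(-c2cc(C)n(S(=O)(=O)Oc3ccccc3)n2)cc1` gives 21.1% in a functional assay on the whole organism for inhibition, with Mus musculus as the target, with stated times of 3 days and 30 min, at a dose of 30 mg/kg by the oral route; on this read-out higher numbers stand for more inhibition at the one dose given (going by the name of the read-out) and lower numbers for less inhibition. Among the three compounds measured, compound 2 stands lowest: compound 3 `O=S(=O)(Oc1ccccc1)n1nc(-c2ccccc2)cc1-c1ccccc1` gives 25.7%, within the scatter of compound 2, whereas compound 1 `Cc1cc(-c2ccc(C(F)(F)F)cc2)nn1S(=O)(=O)Oc1ccccc1` gives 35.9%, beyond it. For the measured compounds named here, the only measured step, a number 14.8 percentage points lower from compound 1 to compound 2 (beyond the scatter), swapped one group on an aromatic carbon and kept the ring. Compound 4 `Cc1cc(-c2ccccn2)nn1S(=O)(=O)Oc1ccccc1` carries a different kind of change, (pyridin-2-yl in place of 4-ethylphenyl on an aromatic carbon). Going by the values given here, no measured step replaces that whole ring, so that one step bears on the change only loosely and gives no direction. The expected step is a number 5.9 percentage points higher from compound 2 to compound 4 (within the scatter), none beyond the scatter, with wide uncertainty. Compound 4 is therefore estimated at 27%, ranging from 10% to 45%.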

Compound 4, a percentage reported as inhibition, in the whole organism at one dose (the size of the read-out at that dose, not a potency): 11.3%
Estimate against measurement, compound 4: 15.7 percentage points above; the range from low to high includes it.
By their numbers in this assay, from the lowest: compounds 4, 2 and 3 (each within the scatter of the next, the first and the last beyond it); then compound 1.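

In this assay the exchange of the whole 4-ethylphenyl ring for pyridin-2-yl at this position gives a number 9.8 percentage points lower from compound 2 to compound 4 (within the scatter) and so stays within the scatter. The earlier step, a number 14.8 percentage points lower from compound 1 to compound 2 (beyond the scatter), changed only the group on the ring and went beyond the scatter, so this ring swap, with a ring nitrogen entering, shows no clear effect of its own. Nothing available here explains either outcome. Going by these compounds, what remains open is whether pyridin-2-yl or the loss of the ethyl group shapes this result, and what an amine or a carboxylic acid on the ring would give.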